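Methoxy in Place of Methyl on a Bridged Core

The source may report more compounds than this note shows. Statements on the series, on what has been measured and on what is new or still open speak of the compounds shown alone.

Of the compounds shown here, two of a shared core have been measured in an assay for binding affinity to Neuronal acetylcholine receptor; alpha4/beta2 (Rattus norvegicus); on this read-out higher numbers stand for weaker inhibition and lower numbers for stronger inhibition. Compound 1 `Oc1ccc2cc3c(cc2n1)C1CNCC3C1` carries a hydroxy group on the aromatic carbon in question, and in this assay compound 1 gives 8.5 nM. Compound 2 `Cc1ccc2cc3c(cc2n1)C1CNCC3C1` carries a methyl group at that same place, and in this assay compound 2 gives 0.76 nM. Among the measured compounds shown here, the single step of an 11-fold lower number from compound 1 to compound 2 (1.05 log units; beyond the scatter) shows that exchanging the hydroxy for a methyl sharpened binding by a wide margin. Among the two measured values, compound 2 stands at the lower end.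

Compound 3 `COc1ccc2cc3c(cc2n1)C1CNCC3C1` differs from compound 2 by one exchange: methoxy in place of methyl on an aromatic carbon. For the measured compounds named here, only the step from compound 1 to compound 2 speaks to this position, and it involved a different group, so no direct comparison of methyl against methoxy exists here. Methoxy shares a carbon with methyl and an oxygen with hydroxy, so a value between the two measured points appears most plausible. The step of a 3.3-fold higher number from compound 2 to compound 3 (0.52 log units; beyond the scatter) is therefore expected to be a moderate weakening. Compound 3 is estimated at 2.5 nM in this assay, with a range from 0.6 nM to 10 nM.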

Compound 3, inhibition constant: 30 nM
The estimate for compound 3 lay 12-fold (1.08 log units) below the measured number; the whole stated range lies below it.
By their numbers in this assay, from the lowest: compound 2; then compound 1; then compound 3.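

In this assay, methoxy does not fall between methyl and hydroxy on this aromatic carbon next to the ring nitrogen: replacing methyl with methoxy gives a 39-fold higher number from compound 2 to compound 3 (1.60 log units; beyond the scatter), a large loss, while adding a methyl to the oxygen of the hydroxy group gives a 3.5-fold higher number from compound 1 to compound 3 (0.55 log units; beyond the scatter), a modest one. Compound 3 therefore has the highest number of the three, with both steps beyond the scatter, so sharing a carbon with methyl brings compound 3 no closer to compound 2. At this position, both groups attached through oxygen give higher numbers than methyl, and capping that oxygen moves the number further from compound 2, yet nothing available here explains this order.

Among the compounds shown here, with only three groups at this carbon, these results cannot show whether the oxygen link itself or the overall size of the group matters more. From the compounds shown here alone, an ethyl group, an amine, a chlorine atom or a plain hydrogen in the same place could help separate those possibilities, and whether any of them would match or beat methyl remains open.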